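The compounds below may be only part of what the source reports. "The series", "measured", "known", "first", "only" and "open" are said of these compounds alone.

In an in vivo functional assay on the whole organism for inhibition, with Rattus norvegicus as the target (a lower number here means that less compound is needed, a higher number that more compound is needed for the effect), compound 1 `CCCCc1nc(C)c(CC(=O)O)c(=O)n1Cc1ccc(-c2ccccc2-c2nnn[nH]2)cc1` gives 0.13 mg/kg, while compound 2 `CCCCc1nc(C)c(CC(=O)N2CCC[C@H]2C(=O)OC)c(=O)n1Cc1ccc(-c2ccccc2-c2nnn[nH]2)cc1` gives 0.043 mg/kg, the lower of the two numbers. Compound 3 `CCCCc1nc(C)c(CC(=O)N2CCC[C@H]2C(N)=O)c(=O)n1Cc1ccc(-c2ccccc2-c2nnn[nH]2)cc1` differs from compound 2 in one small place: amino in place of methoxy on a carbonyl carbon. This puts amino in place of methoxy on a carbonyl carbon, turning methoxycarbonyl into carbamoyl. Going by the values given here, only one measured step is available as a guide: a 3.0-fold lower number from compound 1 to compound 2 (0.48 log units; beyond the scatter). It is modest in size and came from a different exchange, 2-(methoxycarbonyl)pyrrolidin-1-yl in place of hydroxy. Among the compounds with values here, no measured pair shows methoxy replaced by amino, so neither a clear size nor a direction can be drawn from the data, and no step beyond the scatter is expected in this assay. The estimated change is a 1.2-fold higher number from compound 2 to compound 3 (0.07 log units; within the scatter). The expected value for compound 3 is 0.05 mg/kg, with an estimated range from 0.015 mg/kg to 0.15 mg/kg.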

Compound 3, dose for half-maximal effect: 0.023 mg/kg
Compound 3: middle estimate off by 2.2-fold (0.34 log units), on the high side; low and high end bracket the measured number.
By their numbers in this assay, from the lowest: compounds 3 and 2 (each within the scatter of the next); then compound 1.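

In this assay, swapping methoxy for amino on this carbonyl carbon gives a 1.9-fold lower number from compound 2 to compound 3 (0.27 log units; within the scatter) and stays within the scatter, so methoxycarbonyl and carbamoyl cannot be told apart at this position. Both a 3.0-fold lower number from compound 1 to compound 2 (0.48 log units; beyond the scatter) and a 5.7-fold lower number from compound 1 to compound 3 (0.75 log units; beyond the scatter) lie beyond the scatter, so the lower number seen against compound 1 holds with either group on the pyrrolidine ring. Nothing available explains these numbers.

Still open, as far as these compounds go, is whether a carboxylic acid or a dimethylamino amide at this carbonyl carbon would stay in the same range as compound 2 and compound 3. With only these two groups compared, it is also unclear how much change this position can tolerate, or whether a larger group would shift the number beyond the scatter.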